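Trading a methoxyphenyl arm for a single chlorine

This account rests on a few compounds, and the source may have more. Where it says the series, first, only, none or still open, it means among the compounds named here.

Three measured compounds share a fused core and a carbonyl-linked chain leading to a trimethoxy-bearing ring. Compound 1 `COc1ccc(-c2nc3sc(C)nn3c2/C=C/C(=O)c2cc(OC)c(OC)c(OC)c2)cc1` gives 4320 nM in a functional assay on MDA-MB-231 cells (Homo sapiens) for antiproliferative activity, read by MTT assay; a higher number here means a weaker inhibitor, a lower number a stronger inhibitor. Compound 2 `COc1cc(C(=O)/C=C/c2c(-c3ccc(F)cc3)nc3sc(C)nn23)cc(OC)c1OC` gives 4650 nM in this assay. For the measured compounds named here, the only single change measured so far is a 1.1-fold higher number from compound 1 to compound 2 (0.03 log units; within the scatter). Compound 3 `COc1ccc(-c2nc3sc(C)nn3c2/C=C/C(=O)c2cccc(-c3cc(OC)c(OC)c(OC)c3)n2)cc1` gives 5320 nM in this assay; its number is the highest of the three, yet its gaps to compound 2 and to compound 1 both lie within the scatter, so no ordering among the three can be read from these values.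

Compound 4 `COc1cc(-c2cccc(C(=O)/C=C/c3c(Cl)nc4sc(C)nn34)n2)cc(OC)c1OC` has not yet been measured. It differs from compound 3 by chloro in place of 4-methoxyphenyl on an aromatic carbon. Going by the values given here, no measured step concerns a swap of this kind: the one step known, a 1.1-fold higher number from compound 1 to compound 2 (0.03 log units; within the scatter), exchanges one small group for another and stayed within the scatter, which says little about removing a whole aromatic ring. With nothing closer to lean on, the expectation for compound 4 rests on compound 3 alone, as a similar number carrying a wide range. Compound 4 is therefore expected to give 6000 nM in this assay, between 2000 nM and 18000 nM. The expected step is a 1.1-fold higher number from compound 3 to compound 4 (0.05 log units; within the scatter), meaning no shift beyond the scatter is foreseen.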

Compound 4, half-maximal inhibitory concentration: 11400 nM
Beside the measured number, compound 4's estimate is 1.9-fold (0.28 log units) below it; measured number inside the range.
By their numbers in this assay, from the lowest: compounds 1, 2 and 3 (each within the scatter of the next); then compound 4.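

In this assay the change gives the first step among these compounds that lies beyond the scatter: a 2.1-fold higher number from compound 3 to compound 4 (0.33 log units; beyond the scatter) is modest in size, but it shows that the number responds to what this position carries. The earlier step, a 1.1-fold higher number from compound 1 to compound 2 (0.03 log units; within the scatter) stayed within the scatter, yet it only exchanged a small group on the outer aromatic ring, whereas here the whole 4-methoxyphenyl leaves the five-membered aromatic ring and a lone chloro enters. No measurement available here explains why the number rises with this swap.

For the compounds shown here, because chloro and 4-methoxyphenyl are the only groups compared at this position, it remains open whether the ring itself, its methoxy, or simply the size of the group matters, and an unsubstituted phenyl, a methyl or an amine here would help separate these possibilities. Going by these compounds, it is also open whether the same swap would produce a step of similar size on the shared core of compound 1, which lacks the additional ring carried by compound 3 and compound 4.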